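The compounds below may be only part of what the source reports. "The series", "measured", "known", "first", "only" and "open" are said of these compounds alone.

Of the compounds shown here, two that share one core have been tested so far in a functional assay on Jurkat cells (Homo sapiens) for inhibition; a higher number here means a weaker inhibitor, a lower number a stronger inhibitor. Compound 1 `CCOC(=O)c1cnc(N(C)N2C(=O)C=C(C)C2=O)nc1-c1cc2ccccc2s1`, which carries a 1-benzothiophen-2-yl group, gives 130 nM. Compound 2 `CCOC(=O)c1cnc(N(C)N2C(=O)C=C(C)C2=O)nc1-c1nccs1`, which carries a 1,3-thiazol-2-yl group at the same place, gives 1700 nM. This is the higher of the two numbers, which makes compound 2 the weaker inhibitor of the pair. The exchange between these groups produces a 13-fold higher number from compound 1 to compound 2 (1.12 log units; beyond the scatter), a large step well beyond the scatter.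

Compound 3 `CCOC(=O)c1cnc(N(C)N2C(=O)C=C(C)C2=O)nc1-c1ccsc1` keeps the core and changes that group again, with thiophen-3-yl in place of 1,3-thiazol-2-yl on an aromatic carbon. Going by the values given here, the step between the first two compounds is the only measured change at this place, so it alone bears on the new one. Like the group in compound 1, thiophen-3-yl has no ring nitrogen, but it is a single ring, so only part of that large step seems likely to return. In this assay, the expected change is a 3.8-fold lower number from compound 2 to compound 3 (0.58 log units; beyond the scatter), a moderate move toward a lower number. For compound 3, the estimated value is 450 nM, with an expected range from 150 nM to 1300 nM.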

Compound 3, half-maximal inhibitory concentration: 120 nM
Beside the measured number, compound 3's estimate is 3.8-fold (0.57 log units) above it, outside the stated range (below it).
By their numbers in this assay, from the lowest: compounds 3 and 1 (each within the scatter of the next); then compound 2.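

In this assay, replacing 1,3-thiazol-2-yl with thiophen-3-yl gives a 14-fold lower number from compound 2 to compound 3 (1.15 log units; beyond the scatter), even though both groups have the same heavy-atom count and the entering ring has one more carbon in place of the nitrogen. The earlier step could have reflected the loss of a fused ring as well as the loss of the ring nitrogen, but this pair keeps a single five-membered aromatic ring and still shows a large step. The second ring of 1-benzothiophen-2-yl also shows no measurable benefit over thiophen-3-yl, with a 1.1-fold lower number from compound 1 to compound 3 (0.03 log units; within the scatter), so among these three compounds only the nitrogen-bearing group in compound 2 stands apart. Nothing measured here explains why this position responds in this way.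

The two single-ring groups also differ in where the sulfur lies relative to the point of attachment, so the effect of removing the nitrogen cannot be fully separated from that of the changed ring arrangement. A thiophen-2-yl or phenyl group at this place would help to separate them, while a methyl group or an amine on the thiophen-3-yl ring would show how much change the position accepts.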